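The compounds below may be only part of what the source reports. "The series", "measured", "known", "first", "only" and "open" are said of these compounds alone.

Compound 1 `CC(C)Nc1nc(NCc2ccco2)c2ccccc2n1`: 17000 nM
Compound 2 `CSCCNc1nc(NC(C)C)nc2ccccc12`: 20000 nM
Compound 3 `CCOC(=O)CNc1nc(NC(C)C)nc2ccccc12`: > 33000 nM (a limit, not a number)

In an ADME assay on J774.A1 cells (Mus musculus) for cytotoxicity, read by MTT assay, with a stated time of 72 h (a lower number here means that less compound is needed, a higher number that more compound is needed for the effect), compound 1 has one other number to stand against, and the two lie close together: a 1.2-fold higher number from compound 1 to compound 2 (0.07 log units; within the scatter). Compound 4 `Cc1cccc2nc(NC(C)C)nc(NCc3ccco3)c12` keeps the side chains of compound 1 and carries methyl in place of hydrogen on an aromatic carbon. For the measured compounds named here, no measured step tests a change at that place. The measured steps all fall on a saturated chain carbon, and they remain small: an at least 1.9-fold higher number from compound 1 to compound 3 (0.28 log units; that floor lies within the scatter), and an at least 1.6-fold higher number from compound 2 to compound 3 (0.21 log units; that floor lies within the scatter). No step beyond the scatter is therefore expected, in either direction. The estimated step is a 1.1-fold lower number from compound 1 to compound 4 (0.03 log units; within the scatter). For compound 4 the expected value is 16000 nM, with an estimated range of 8000 nM to 32000 nM.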

Compound 4, half-maximal effective concentration: 20000 nM
Compound 4: the middle estimate sits 1.3-fold (0.10 log units) below what was measured, and the stated range covers the measured number.
By their numbers in this assay, from the lowest: compounds 1, 2 and 4 (each within the scatter of the next). At a limit, above all of these: compound 3.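

Methyl in place of hydrogen on an aromatic carbon, ortho to a fused ring and meta to a fused ring, gives in this assay the first reading at a place on the shared core rather than on a side chain: a 1.2-fold higher number from compound 1 to compound 4 (0.07 log units; within the scatter). For the compounds shown here, this position, unlike the saturated chain carbon of the earlier steps, has now been tested, and methyl there leaves the number within the scatter. Nothing shown here gives a cause for this. As far as these compounds go, what an amine, a carboxylic acid or a longer chain would do at this carbon remains open, as do the other aromatic carbons of the core.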